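The source may hold more compounds than are shown below. What is called first, only, known or untested is meant among the compounds shown, and "the series" means these compounds.

Measured so far in a functional assay on A549 cells (Homo sapiens) for antiproliferative activity, read by MTT assay, with a stated time of 72 h; a lower number here means a stronger inhibitor, a higher number a weaker inhibitor:
compound 1 `COc1cc2ncnc(Nc3ccc(Cl)c(C(F)(F)F)c3)c2cc1OCCCCC(=O)Nc1ccc(S(N)(=O)=O)cc1` gives 9270 nM;
compound 2 `COc1cc2ncnc(Nc3cccc(C)c3)c2cc1OCCCCC(=O)Nc1ccc(S(N)(=O)=O)cc1` gives 16000 nM.

Compound 2 holds the highest of the two numbers, its nearest neighbour compound 1 differing by only a 1.7-fold higher number from compound 1 to compound 2 (0.24 log units; within the scatter), a step that stays within the scatter. Compound 3 `COc1cc2ncnc(Nc3cc(F)c(F)c(F)c3)c2cc1OCCCCC(=O)Nc1ccc(S(N)(=O)=O)cc1` carries the change (3,4,5-trifluorophenyl in place of 3-methylphenyl on a nitrogen on an aromatic ring). Going by the values given here, the only step that bears on it, that from compound 1 to compound 2, exchanged a halogenated ring for the methyl-bearing ring without a change beyond the scatter; on that basis no step beyond the scatter is expected for compound 3, perhaps a slight drift back toward the number of compound 1. Compound 3 is therefore estimated at 11000 nM, within 4000 nM to 30000 nM, an expected step of a 1.5-fold lower number from compound 2 to compound 3 (0.16 log units; within the scatter).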

Compound 3, half-maximal inhibitory concentration: > 40000 nM
Compound 3: a limit, no number; the forecaster's own chance of this, stated with the estimate: 15%; at least 3.6-fold (0.56 log units) between middle value and limit.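

For compound 3 the result in this assay is a limit and not a number: the limit of > 40000 nM in this assay, at which 1 of the 3 values shown sits. The group on the nitrogen on an aromatic ring is not indifferent, as 3,4,5-trifluorophenyl gives an at least 2.5-fold higher number from compound 2 to compound 3 (0.39 log units; beyond the scatter) and an at least 4.3-fold higher number from compound 1 to compound 3 (0.63 log units; beyond the scatter). Halogen on this ring as such therefore does not keep the number near that of compound 1, which gives 9270 nM.

On these data alone, how far compound 3 lies past its limit stays open. Also open is whether 3-aminophenyl or 3-carboxyphenyl on the same nitrogen would give a lower number than any shown.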